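Swapping a chlorophenyl for a methoxypyridyl on the amide

A few compounds are considered here, and "the series" means these few. Any claim that something is new, unique, unknown or untested is made for them only; others in the source may bear on it.

Three measured compounds share one core and differ only in the group on the amide-type nitrogen. Compound 1 `O=C(NCc1ccccc1)c1c(O)c2cccnc2n(-c2ccccc2)c1=O` gives 1.6% in a functional assay on the whole organism for inhibition, with Rattus norvegicus as the target, read by paw edema, at a dose of 100 mg/kg by the oral route; a lower number here means less inhibition, a higher number more inhibition at the dose given (going by the name of the read-out). Compound 2 `CN(C)CCNC(=O)c1c(O)c2cccnc2n(-c2ccccc2)c1=O` gives 22.6% in this assay, and compound 3 `O=C(Nc1ccc(Cl)cc1)c1c(O)c2cccnc2n(-c2ccccc2)c1=O` gives 11.6%. Compound 3 stands second highest of the three: a number 10 percentage points higher from compound 1 to compound 3 (within the scatter) lies within the scatter, while a number 11 percentage points lower from compound 2 to compound 3 (beyond the scatter) is modest but beyond it. Compound 4 `COc1ccc(NC(=O)c2c(O)c3cccnc3n(-c3ccccc3)c2=O)cn1` differs from compound 3 by 6-methoxypyridin-3-yl in place of 4-chlorophenyl on an amide-type nitrogen. The earlier changes at the amide nitrogen moved this assay by a number 21 percentage points higher from compound 1 to compound 2 (beyond the scatter) and by a number 11 percentage points lower from compound 2 to compound 3 (beyond the scatter), both modest. For the measured compounds named here, no measured step exchanges one aromatic ring for another here, so compound 4 is expected to show a number 2.4 percentage points higher from compound 3 to compound 4 (within the scatter), within the scatter. Compound 4 is estimated at 14%, between 2% and 30%.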

Compound 4, a percentage reported as inhibition, in the whole organism at one dose (the size of the read-out at that dose, not a potency): 13.1%
Estimate against measurement, compound 4: 0.9 percentage points above; measured number inside the range.
By their numbers in this assay, from the lowest: compounds 1, 3, 4 and 2 (each within the scatter of the next, the first and the last beyond it).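

In this assay, 6-methoxypyridin-3-yl in place of 4-chlorophenyl on the amide-type nitrogen gives a number 1.5 percentage points higher from compound 3 to compound 4 (within the scatter), so this first exchange of one aromatic ring for another shows no measurable change. For the compounds shown here, the other two steps place compound 4 among the earlier compounds: a number 9.5 percentage points lower from compound 2 to compound 4 (within the scatter), and a number 11.5 percentage points higher from compound 1 to compound 4 (beyond the scatter). Going by these compounds alone, only the step from the benzyl compound clears the scatter, and it is modest.

Nothing available explains why the two rings read alike. On these data alone, whether a pyridin-3-yl without the methoxy, or a phenyl carrying a carboxylic acid, would read differently stays open.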